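The source may hold more compounds than are shown below. What is called first, only, known or untested is meant among the compounds shown, and "the series" means these compounds.

Working notes on the series built on the core of compound 1 `CN1CCC(COc2ccc3c(Nc4ccc(NC(=O)Nc5ccc(Cl)c(C(F)(F)F)c5)cc4)ncnc3c2)CC1`. In a functional assay on HUVEC cells (Homo sapiens) for antiproliferative activity, read by sulforhodamine B assay, with a stated time of 48 h (on this read-out lower numbers stand for stronger inhibition and higher numbers for weaker inhibition), compound 1 gives 92 nM and compound 2 `CN1CCC(COc2ccc3c(Nc4ccc(NC(=O)Nc5ccc(Br)cc5F)cc4)ncnc3c2)CC1` gives 233 nM, while compound 3 `CN1CCC(COc2ccc3c(Nc4ccc(NC(=O)NC5CC5)cc4)ncnc3c2)CC1` gives 324 nM and carries cyclopropyl on an amide-type nitrogen. Compound 3 cannot be separated from compound 2, as a 1.4-fold higher number from compound 2 to compound 3 (0.14 log units; within the scatter) shows, but it is separated from compound 1 by a 3.5-fold higher number from compound 1 to compound 3 (0.55 log units; beyond the scatter) on the weaker side.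

Compound 4 `Cc1ccc(NC(=O)Nc2ccc(Nc3ncnc4cc(OCC5CCN(C)CC5)ccc34)cc2)cc1Br` has 3-bromo-4-methylphenyl in place of that cyclopropyl (3-bromo-4-methylphenyl in place of cyclopropyl on an amide-type nitrogen). The two steps just given bear most directly on this change when read in reverse, since each links a substituted phenyl with cyclopropyl at the same nitrogen. One is modest and beyond the scatter, and the other is not. The step of a 2.5-fold higher number from compound 1 to compound 2 (0.40 log units; beyond the scatter) shows that the phenyl substituents alone can also shift the number modestly, so the size of the gain is uncertain.

A modest move to a lower number is expected in this assay, estimated as a 2.2-fold lower number from compound 3 to compound 4 (0.33 log units; beyond the scatter) and only a little past the scatter. For compound 4 the estimated value is 150 nM with an expected range from 60 nM to 350 nM in this read-out.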

Compound 4, half-maximal inhibitory concentration: 196 nM
The estimate for compound 4 lay 1.3-fold (0.12 log units) below the measured number; measured number inside the range.
By their numbers in this assay, from the lowest: compound 1; then compounds 4, 2 and 3 (each within the scatter of the next).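

In this assay the step to 3-bromo-4-methylphenyl on the amide-type nitrogen stays within the scatter (a 1.7-fold lower number from compound 3 to compound 4 (0.22 log units; within the scatter)), and so does the comparison with 4-bromo-2-fluorophenyl at the same place (a 1.2-fold lower number from compound 2 to compound 4 (0.08 log units; within the scatter)), so among compounds 2, 3 and 4 a substituted phenyl cannot be separated from cyclopropyl. Among the compounds shown here, compound 1 stands apart from this group, now also against a third substituent set (a 2.1-fold higher number from compound 1 to compound 4 (0.33 log units; beyond the scatter)), and it is the most potent of the four, with 4-chloro-3-(trifluoromethyl)phenyl the only group at this place that is separated from cyclopropyl. Nothing measured here gives a reason for this separation or bears on how the groups act at this nitrogen.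

Whether the separation of compound 1 needs both the chlorine and the trifluoromethyl group remains open, since compounds carrying only one of the two are absent from the compounds shown. Also open, on these data alone, is how this position responds to a group of another kind on the same nitrogen, such as a longer alkyl chain, a chain ending in an amine or a carboxylic acid.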